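A few compounds are considered here, and "the series" means these few. Any claim that something is new, unique, unknown or untested is made for them only; others in the source may bear on it.

Measured so far in a functional assay (aorta) with Oryctolagus cuniculus as the target; a higher number here means weaker binding, a lower number tighter binding:
compound 1 `COc1cc(C(C)=O)ccc1OCCCN1CCC(Cc2ccc(F)cc2)CC1` gives 20 nM
compound 2 `COc1cc(C(C)=O)ccc1OCCCN1CCC(CC(c2ccc(F)cc2)c2ccc(F)cc2)CC1` gives 3.16 nM
compound 3 `COC(=O)c1ccc(OCCCN2CCC(C(c3ccc(F)cc3)c3ccc(F)cc3)CC2)c(OC)c1` gives 1.26 nM

Compound 3 stands lowest of the three numbers in this assay; its nearest neighbour is compound 2, already beyond the usual scatter, and its furthest is compound 1. Compound 4 `Fc1ccc(C(c2ccc(F)cc2)C2CCN(CCCOc3ccccc3)CC2)cc1` differs from compound 3 in one place: phenyl in place of 2-methoxy-4-(methoxycarbonyl)phenyl on an oxygen on a saturated carbon. The phenyl that enters is smaller than the group that leaves and carries no hydrogen-bond acceptors. Going by the values given here, no measured pair shows this change, so its size is not known from the data. In this assay the step is expected to be a 4.8-fold higher number from compound 3 to compound 4 (0.68 log units; beyond the scatter), a move toward weaker binding that goes beyond the scatter. Compound 4 is therefore estimated at 6 nM, with a range from 1.5 nM to 25 nM.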

Compound 4, dissociation constant: 1.59 nM
For compound 4 the middle estimate is 3.8-fold (0.58 log units) above the measured one; the measured number falls inside the stated range.
By their numbers in this assay, from the lowest: compounds 3, 4 and 2 (each within the scatter of the next, the first and the last beyond it); then compound 1.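

Replacing 2-methoxy-4-(methoxycarbonyl)phenyl with phenyl on an oxygen on a saturated carbon gives, in this assay, a 1.3-fold higher number from compound 3 to compound 4 (0.10 log units; within the scatter) and so no change that can be told from the scatter. On the core of compound 3, the methoxy and methoxycarbonyl substituents are therefore not needed to hold a number in this range at this position. Nothing available accounts for this result.

Still open, as far as these compounds go, is whether a carboxylic acid, an amine or a pyridine ring in place of the phenyl would be tolerated equally. Also open, from the compounds shown here alone, is whether the same replacement behaves alike on the cores of compound 1 and compound 2.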